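The compounds below may be only part of what the source reports. "The series", "measured", "known", "first", "only" and "open" are said of these compounds alone.

In a physicochemical assay for lipophilicity, read by LC-MS, in phosphate buffer, measured as octanol-water partition, at pH 7.4, tested at 66.7 uM (on this read-out higher numbers stand for higher lipophilicity and lower numbers for lower lipophilicity), compound 2 `CN1CCN(c2ccc(Nc3nccc(-c4ccc5ccccc5c4)n3)cc2C(F)(F)F)CC1` reads > 5.7, which is a limit of the assay and not a number. The closest comparison is compound 1 `CN1CCN(c2ccc(Nc3nccc(-c4ccccc4)n3)cc2C(F)(F)F)CC1`, which gives 4.8 and carries phenyl where compound 2 carries naphthalen-2-yl. Going by the values given here, that swap is the only measured step here, and it is a number at least 0.90 log units higher from compound 1 to compound 2 (beyond the scatter).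

Compound 3 `CN1CCN(c2ccc(Nc3nccc(-c4cnn5ncccc45)n3)cc2C(F)(F)F)CC1` is made from compound 2 by a single change: a group of 9 heavy atoms (6 carbon, 3 nitrogen; one five-membered aromatic ring with 2 hetero atoms, one six-membered aromatic ring with 2 hetero atoms) in place of a group of 10 heavy atoms (10 carbon; 2 six-membered aromatic rings of carbon only), on an aromatic carbon. The naphthalen-2-yl group leaves, and a group of about the same size takes its place on the aromatic carbon, but this one contains nitrogen and counts hydrogen-bond acceptors. Among the compounds with values here, no measured step tests this exact swap, so any forecast is a judgement. The best guide is compound 2, whose rise over compound 1 came with the group now leaving, as a number at least 0.90 log units higher from compound 1 to compound 2 (beyond the scatter) shows. That rise should be lost, and the value may fall somewhat further, to the region of compound 1 or lower.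

The expected change is a number at least 1.40 log units lower from compound 2 to compound 3 (beyond the scatter), a fall well beyond the scatter. For compound 3 the estimated value in this assay is 4.3, with an expected range of 3.7 to 4.9.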

Compound 3, distribution coefficient: 3.71
Beside the measured number, compound 3's estimate is 0.59 log units above it, within the range that was stated.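

Going by these compounds alone, the position now moves the reading in both directions, where the earlier compounds showed only a rise on going from phenyl to naphthalen-2-yl: the group with 3 nitrogen gives a number at least 1.99 log units lower from compound 2 to compound 3 (beyond the scatter), and it gives a number 1.09 log units lower from compound 1 to compound 3 (beyond the scatter). The second of these steps matters more as a measure, since compound 2 stands at a limit of the assay and not at a number, so its step gives only a bound: the limit of > 5.7 in this assay, at which 1 of the 3 values shown sits. Heavy-atom count alone does not order these three compounds, as the entering group has more heavy atoms than phenyl and fewer than naphthalen-2-yl by only one, yet compound 3 reads lowest of the three, with both of its steps printed as beyond the scatter.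

The compounds shown cannot tell whether the fall follows the number of ring nitrogen atoms, their placing, or the pairing of a five-membered with a six-membered ring. Nor do they show where a single ring holding one nitrogen, such as pyridin-3-yl, or a phenyl carrying a methoxy group, would fall on this aromatic carbon.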